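The source may report more compounds than this note shows. Statements on the series, on what has been measured and on what is new or still open speak of the compounds shown alone.

Measured in an ADME assay on Vero cells (Chlorocebus sabaeus) for cytotoxicity, read by MTT assay, with a stated time of 72 h; on this read-out lower numbers stand for higher toxicity in this test and higher numbers for lower toxicity in this test:
compound 1, `CCO/N=C1\C(=O)N(CCCCCOc2ccc3oc(-c4ccc(OC)cc4)c(C(=O)OCC)c3c2)c2ccc(F)cc21`: 32 ug/mL
compound 2, `CCOC(=O)c1c(-c2ccc(OC)cc2)oc2ccc(OCCCCCCN3C(=O)/C(=N\OC)c4cc(F)ccc43)cc12`: 16 ug/mL
compound 3, `CCO/N=C1\C(=O)N(CCCCCOc2ccc3oc(-c4ccc(OC)cc4)c(C(=O)OCC)c3c2)c2ccc(OC)cc21`: 16 ug/mL

Compound 3 and compound 1 differ in one place, (fluoro in place of methoxy on an aromatic carbon); the step is a 2.0-fold higher number from compound 3 to compound 1 (0.30 log units; within the scatter). Compound 2 stands level with compound 3 at the digits shown, and the difference between their two cores is not broken down here. Compound 4, `CCOC(=O)c1c(-c2ccc(F)cc2)oc2ccc(OCCCCCCN3C(=O)/C(=N\OC)c4cc(F)ccc43)cc12`, is not yet measured; from compound 2 it differs by fluoro in place of methoxy on an aromatic carbon. This is the same kind of change as that seen between compound 3 and compound 1, but the place differs: in compound 4 the aromatic carbon sits in a six-membered aromatic ring of carbon only, para to a large group, whereas in compound 1 it sits in a ring that is part of a fused or bridged system of two rings, meta to a fused ring and para to a fused ring. The step expected in this assay is a 1.4-fold higher number from compound 2 to compound 4 (0.14 log units; within the scatter). This rests on a 2.0-fold higher number from compound 3 to compound 1 (0.30 log units; within the scatter). Compound 4 is accordingly estimated at 22 ug/mL, within 10 ug/mL to 50 ug/mL.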

Compound 4, half-maximal cytotoxic concentration: 16 ug/mL
Beside the measured number, compound 4's estimate is 1.4-fold (0.14 log units) above it, and the stated range covers the measured number.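

In this assay, fluoro in place of methoxy gives no change at the digits printed from compound 2 to compound 4 (within the scatter), with 4-methoxyphenyl going to 4-fluorophenyl on the core of compound 2. Set beside the earlier case, on a different aromatic carbon, the two steps cannot be told apart: the same change on two cores in this assay, a 2.0-fold higher number (0.30 log units; within the scatter) from compound 3 to compound 1 and no change at the digits printed (within the scatter) from compound 2 to compound 4, 2.0-fold (0.30 log units) apart, within the scatter of two such steps. This shows that the change behaves alike on these two cores as far as this read-out can tell, but with both steps inside the scatter, it does not show that the change has any effect of its own or that it would carry to a third core.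

Still open, going by these compounds, is how the read-out responds to an amine or a carboxylic acid on that aromatic carbon. On these data alone, a longer chain between the two halves of the molecule also remains open.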